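Para-substituent on the pendant phenyl of the chalcone series

A few compounds are considered here, and "the series" means these few. Any claim that something is new, unique, unknown or untested is made for them only; others in the source may bear on it.

Measured compounds in a functional assay on OVCAR-4 cells (Homo sapiens) for inhibition; a higher number here means a weaker inhibitor of growth, a lower number a stronger inhibitor of growth:
compound 1 `COc1cc(/C=C/C(=O)c2cccc(-n3cc(-c4ccc(Cl)cc4)[nH]c3=O)c2)cc(OC)c1OC`, 11400 nM
compound 2 `O=C(/C=C/c1cccc(O)c1)c1cccc(-n2cc(-c3ccc(Cl)cc3)[nH]c2=O)c1`, 2210 nM
compound 3 `COc1cc(/C=C/C(=O)c2cccc(-n3cc(-c4ccccc4)[nH]c3=O)c2)cc(OC)c1OC`, 1880 nM

Compound 3 gives the lowest of the three numbers in this assay, but its gap to compound 2 lies within the scatter, so the two cannot be ordered; only compound 1 stands clearly apart, with a higher number.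

Compound 4 `COc1ccc(-c2cn(-c3cccc(C(=O)/C=C/c4cc(OC)c(OC)c(OC)c4)c3)c(=O)[nH]2)cc1` is the next member and differs from compound 3 in one place: methoxy in place of hydrogen on an aromatic carbon. Within the data shown here, the only measured step at that aromatic carbon is a 6.1-fold lower number from compound 1 to compound 3 (0.78 log units; beyond the scatter), where removing a chloro group gave a markedly lower number. Among the measured compounds shown here, no measured pair shows a methoxy group at that place, so the size of its effect is not known from this series. For the measured compounds named here, the single step available suggests that a group at this carbon tends to raise the number, though a methoxy group need not behave as chloro did.

For compound 4 the number in this assay is therefore expected to rise modestly, a 1.9-fold higher number from compound 3 to compound 4 (0.27 log units; within the scatter), to an estimated 3500 nM, with a range of 1200 nM to 10000 nM.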

Compound 4, concentration for 50% growth inhibition: 3570 nM
Compound 4: middle estimate off by 1.0-fold (0.01 log units), on the low side; low and high end bracket the measured number.
By their numbers in this assay, from the lowest: compounds 3, 2 and 4 (each within the scatter of the next); then compound 1.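

In this assay methoxy in place of hydrogen on this aromatic carbon, phenyl to 4-methoxyphenyl, gives a change that stays within the scatter (a 1.9-fold higher number from compound 3 to compound 4 (0.28 log units; within the scatter)). Methoxy in place of chloro at the same carbon gives a step beyond the scatter (a 3.2-fold lower number from compound 1 to compound 4 (0.50 log units; beyond the scatter)), so a substituent here does not by itself carry the penalty seen with chloro, and the identity of the group matters: of the three groups tested on this core, only chloro stands clearly apart. Nothing available here accounts for the difference between chloro and methoxy at this carbon.

As far as these compounds go, whether an amine, a carboxylic acid or a longer alkoxy chain at this carbon would fall with hydrogen and methoxy or with chloro remains open. Also open, from the compounds shown here alone, is whether the same ordering holds with the pendant hydroxyphenyl of compound 2 in place of the trimethoxyphenyl group.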